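Removing dimethylamino from compound 1

The source may hold more compounds than are shown below. What is called first, only, known or untested is meant among the compounds shown, and "the series" means these compounds.

For the measured compounds named here, in a functional assay on DWD cells (Homo sapiens) for inhibition, read by sulforhodamine B assay (on this read-out higher numbers stand for weaker inhibition of growth and lower numbers for stronger inhibition of growth), compound 1 `Cc1ccc2[nH]c(-c3ccc(-c4ccc(-c5ccc(N(C)C)cc5)cc4)cc3)nc2c1` gives 3230 nM, the lower of the two numbers so far, and compound 2 `CN(C)c1ccc(-c2ccc(-c3ccc(-c4nc5ccccc5[nH]4)cc3)cc2)cc1` gives 100000 nM. Compound 3 `Cc1ccc2[nH]c(-c3ccc(-c4ccc(-c5ccccc5)cc4)cc3)nc2c1` keeps the core of compound 1 but has hydrogen in place of dimethylamino on an aromatic carbon, para to a large group: hydrogen in place of dimethylamino on an aromatic carbon. The same difference reads as 4-(dimethylamino)phenyl to phenyl. Going by the values given here, no measured step covers this change. Among the compounds with values here, the only one, a 31-fold higher number from compound 1 to compound 2 (1.49 log units; beyond the scatter), is hydrogen in place of methyl at a different place, and it shows only that a single change can move a number far beyond the scatter. A higher number is therefore expected, though its size is poorly constrained. The expected step is a 2.5-fold higher number from compound 1 to compound 3 (0.39 log units; beyond the scatter). For compound 3 the estimate is 8000 nM, with an expected range of 1500 nM to 50000 nM.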

Compound 3, concentration for 50% growth inhibition: 28300 nM
The estimate for compound 3 lay 3.5-fold (0.55 log units) below the measured number; measured number inside the range.
By their numbers in this assay, from the lowest: compound 1; then compound 3; then compound 2.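

In this assay, hydrogen in place of dimethylamino on this aromatic carbon gives an 8.8-fold higher number from compound 1 to compound 3 (0.94 log units; beyond the scatter), so this position, para to a large group, also affects inhibition of growth. Alongside a 31-fold higher number from compound 1 to compound 2 (1.49 log units; beyond the scatter), this gives two single changes that raise the number beyond the scatter, one at each end of the molecule, and neither improves on the lowest number in the series. Nothing measured here explains the step.

Still open, on these data alone, is whether dimethylamino is specifically favoured at this position, or whether a smaller amine, a methoxy group or a carboxylic acid would hold or lower the number. Also open, as far as these compounds go, is whether a methyl group at the other place and a group at this position contribute independently.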